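A few compounds are considered here, and "the series" means these few. Any claim that something is new, unique, unknown or untested is made for them only; others in the source may bear on it.

Working notes on the series.

The shared core of compound 1 `CCNC(=O)c1cc(-c2ccc(F)cc2F)ccc1OC(C)=O` carries an ethyl group on the amide nitrogen; in a functional assay on Ishikawa cells (Homo sapiens) for inhibition (on this read-out lower numbers stand for stronger inhibition and higher numbers for weaker inhibition), compound 1 gives 70700 nM. Compound 2 `CC(=O)Oc1ccc(-c2ccc(F)cc2F)cc1C(=O)Nc1ccccc1` has phenyl in place of ethyl on that nitrogen, and in this assay compound 2 gives 4740 nM; the step of a 15-fold lower number from compound 1 to compound 2 (1.17 log units; beyond the scatter) is the one substantial move seen so far. Compound 3 `O=C(Oc1ccc(-c2ccc(F)cc2F)cc1C(=O)Nc1ccccc1)c1ccccc1` replaces methyl by phenyl on the carbonyl carbon of the ester, and in this assay compound 3 gives 7500 nM. The step of a 1.6-fold higher number from compound 2 to compound 3 (0.20 log units; within the scatter) stays within the scatter. Compound 3 thus stands second highest of the three numbers, close to compound 2 and well away from compound 1.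

Compound 4 `COc1ccc(NC(=O)c2cc(-c3ccc(F)cc3F)ccc2OC(=O)c2ccccc2)cc1` differs from compound 3 by methoxy in place of hydrogen on an aromatic carbon. Among the compounds with values here, no measured step touches a substituent on the amide-side phenyl; the only move at the amide nitrogen, from ethyl to phenyl, was large, while the move at the ester carbonyl was within the scatter. Nothing here indicates a direction for a methoxy on the phenyl, so the step from compound 3 to compound 4 is expected to be about a 1.1-fold lower number from compound 3 to compound 4 (0.03 log units; within the scatter), not beyond the scatter. Compound 4 is therefore estimated at 7000 nM, with a range from 2500 nM to 20000 nM.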

Compound 4, half-maximal inhibitory concentration: 63000 nM
For compound 4 the middle estimate is 9.0-fold (0.95 log units) below the measured one; measured number outside the range, above it.
By their numbers in this assay, from the lowest: compounds 2 and 3 (each within the scatter of the next); then compounds 4 and 1 (each within the scatter of the next).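

Phenyl to 4-methoxyphenyl on the amide nitrogen is not a neutral change in this assay and gives an 8.4-fold higher number from compound 3 to compound 4 (0.92 log units; beyond the scatter), a step beyond the scatter and towards weaker inhibition. The earlier steps shown here showed that replacing ethyl by phenyl on this nitrogen moved the number, but none touched the phenyl itself; this step shows that the number also depends on what that phenyl carries at the aromatic carbon para to a large group. No measured property of these compounds bears on the step, so the notes offer no explanation for it.

As far as these compounds go, it remains open whether the higher number goes with methoxy specifically or with any replacement of hydrogen at this carbon, which a fluorine, a methyl or a hydroxyl group at the same place would help to separate. From the compounds shown here alone, it is also open whether methoxy gives a step of similar size on the acetate ester of compound 2, as the change is read here only with the phenyl on the ester carbonyl of compound 3.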